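The source may report more compounds than this note shows. Statements on the series, on what has been measured and on what is new or still open speak of the compounds shown alone.

Compound 1 `Cc1cc(Nc2cc(N3CCN(C)CC3)nc(Nc3ccc(S(N)(=O)=O)cc3)n2)n[nH]1` gives 12200 nM in a functional assay on HCT-116 cells (Homo sapiens) for antiproliferative activity, read by CCK-8 assay, with a stated time of 72 h (on this read-out lower numbers stand for stronger inhibition and higher numbers for weaker inhibition), the highest of the two numbers recorded so far. Compound 2 `COc1cccc(Nc2nc(Nc3cc(C)[nH]n3)cc(N3CCN(C)CC3)n2)c1` gives 923 nM in this assay, and the step of a 13-fold lower number from compound 1 to compound 2 (1.12 log units; beyond the scatter) came with 3-methoxyphenyl in place of 4-sulfamoylphenyl on a nitrogen on an aromatic ring. Compound 3 `COc1ccc(Nc2nc(Nc3cc(C)[nH]n3)cc(N3CCN(C)CC3)n2)cc1` differs from compound 1 by methoxy in place of sulfamoyl on an aromatic carbon. That step from compound 1 to compound 2 is the only one that bears here, and it swaps the same leaving group for a methoxy at another place, so a clearly lower number is expected for compound 3, perhaps less pronounced. Compound 3 is estimated at 1800 nM, between 500 nM and 6500 nM, a step of a 6.8-fold lower number from compound 1 to compound 3 (0.83 log units; beyond the scatter).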

Compound 3, half-maximal inhibitory concentration: 2240 nM
The estimate for compound 3 lay 1.2-fold (0.09 log units) below the measured number; measured number inside the range.
By their numbers in this assay, from the lowest: compound 2; then compound 3; then compound 1.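

Replacing sulfamoyl with methoxy on this aromatic carbon gives a 5.4-fold lower number from compound 1 to compound 3 (0.74 log units; beyond the scatter) in this assay and so lowers the number here as well, not only with the 3-methoxyphenyl of compound 2. Where the methoxy sits still counts: 4-methoxyphenyl in place of 3-methoxyphenyl gives a 2.4-fold higher number from compound 2 to compound 3 (0.39 log units; beyond the scatter) and so leaves compound 3 short of compound 2.

As far as these compounds go, whether methoxy itself helps or only the loss of sulfamoyl does stays open, and a hydrogen, an amine or a chlorine on that carbon would separate the two. Nothing measured here accounts for either step.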